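This account rests on a few compounds, and the source may have more. Where it says the series, first, only, none or still open, it means among the compounds named here.

Measured so far: compound 1 `CC(C)c1cccc(C(C)C)c1OS(=O)(=O)NC(=O)O[C@@H]1C[C@H](C)CCC1C(C)C`, 21000 nM; compound 2 `CC(C)c1cccc(C(C)C)c1OS(=O)(=O)NC(=O)Oc1cccnc1`. For compound 2 only a limit is known.

In an assay on liver for inhibition of sterol O-acyltransferase 1 (Rattus norvegicus), using microsomes (a lower number here means a stronger inhibitor, a higher number a weaker inhibitor), compound 1 gives 21000 nM. For compound 2 this assay returns only a limit, > 50000 nM, so compound 2 stands at the limit of > 50000 nM in this assay, at which 1 of the 2 values shown sits, and no number is known for it. Among the measured compounds shown here, the single measured step, an at least 2.3-fold higher number from compound 1 to compound 2 (0.37 log units; beyond the scatter), concerns a different exchange and bears on the next step only loosely. Compound 3 `CC(C)c1cccc(C(C)C)c1OS(=O)(=O)NC(=O)Oc1ccc(F)cc1` carries 4-fluorophenyl in place of pyridin-3-yl on an oxygen next to a carbonyl group. With compound 2 at the limit, the expected step of an at least 1.2-fold lower number from compound 2 to compound 3 (0.09 log units; that floor lies within the scatter) is small and uncertain in direction. The value for compound 3 is estimated at 40000 nM, range 10000 nM to 150000 nM.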

Compound 3, half-maximal inhibitory concentration: > 50000 nM
Compound 3 was reported as a limit (the forecaster's own chance of this, stated with the estimate: 50%); middle value at least 1.2-fold (0.09 log units) away from the limit.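

Compound 3 gives > 50000 nM in this assay, which is a limit and not a number. With 4-fluorophenyl in place of 2-isopropyl-5-methylcyclohexyl, the series shows an at least 2.3-fold higher number from compound 1 to compound 3 (0.37 log units; beyond the scatter), so a carbon-only aromatic ring at this oxygen reads the same way as pyridin-3-yl did. The step between compound 2 and compound 3 cannot be read, and both aromatic groups now sit at the same limit: the limit of > 50000 nM in this assay, at which 2 of the 3 values shown sit.

On these data alone, how far compound 2 and compound 3 lie past that limit stays open. Also open, as far as these compounds go, is whether a straight hexyl chain on this oxygen would give a lower number than compound 1.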